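The source may hold more compounds than are shown below. What is called first, only, known or untested is meant among the compounds shown, and "the series" means these compounds.

Measured compounds:
compound 1 `CNc1ncc(C#Cc2ccc(C)cc2)cn1` — 704000 nM
compound 2 `Cc1cccc(C#Cc2cnc(C)nc2)c1` — "not active" (no number reported)
compound 3 `COc1ncc(C#Cc2ccccc2)cn1` — "not active" (no number reported)

Going by the values given here, in an assay on HEK293 cells for positive allosteric modulation of metabotropic glutamate receptor 5 (Rattus norvegicus) (on this read-out lower numbers stand for an effect already at smaller amounts and higher numbers for an effect only at larger amounts of compound), compound 1 gives 704000 nM, the only number in this set. Compound 2 gives "not active" (no number reported), and so stands with compound 3, which gives "not active" (no number reported), among the entries without a number; only compound 1 carries a value. Compound 4 `Cc1cccc(C#Cc2cnc(C(C)(C)C)nc2)c1` differs from compound 2 by tert-butyl in place of methyl on an aromatic carbon. Among the compounds with values here, since compound 2 has no number, no size can be given to this step in this assay, and nothing among the measured compounds points to a gain. Compound 4 is therefore expected to show at most a weak effect, estimated at 500000 nM with a range from 100000 nM to 2000000 nM, and it may well again return no number.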

Compound 4, half-maximal effective concentration: "not active" (no number reported)
The entry for compound 4 holds no number; the estimate stays without a comparison.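

Going by these compounds alone, neither compound 2 nor compound 4 carries a number, and no step between them can be read. The compounds shown leave open whether tert-butyl or methyl in that place matters at all. No supporting evidence bears on this result.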